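The compounds below may be only part of what the source reports. "The series", "measured", "known", "first", "only" and "open" are said of these compounds alone.

Series notes. Compound 1 `Clc1cccc(Nc2ncnc3ccc(NCc4cccs4)cc23)c1` and compound 2 `O=C(/C=C/c1ncc2ccccc2n1)Nc1ccc2ncnc(Nc3cccc(Cl)c3)c2c1` share a core and differ in one side chain. In a functional assay on HepG2 cells (Homo sapiens) for antiproliferative activity, read by MTT assay, with a stated time of 48 h (on this read-out higher numbers stand for weaker inhibition and lower numbers for stronger inhibition), compound 1 gives 3580 nM, and compound 2 gives 7790 nM, the highest of the two numbers and beyond the scatter from compound 1. Compound 3 `O=C(/C=C/c1cccs1)Nc1ccc2ncnc(Nc3cccc(Cl)c3)c2c1` carries thiophen-2-yl in place of quinazolin-2-yl on a double-bonded chain carbon bound to a double-bonded chain carbon. For the measured compounds named here, no measured pair isolates this change, so the expected step is small, a 1.6-fold lower number from compound 2 to compound 3 (0.19 log units; within the scatter), toward a lower number if anything, and may stay within the scatter. Compound 3 is expected to give 5000 nM in this assay, with a range from 1500 nM to 16000 nM.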

Compound 3, half-maximal inhibitory concentration: 10400 nM
Beside the measured number, compound 3's estimate is 2.1-fold (0.32 log units) below it; the measured number falls inside the stated range.
By their numbers in this assay, from the lowest: compound 1; then compounds 2 and 3 (each within the scatter of the next).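

In this assay, thiophen-2-yl in place of quinazolin-2-yl on a double-bonded chain carbon bound to a double-bonded chain carbon gives a 1.3-fold higher number from compound 2 to compound 3 (0.13 log units; within the scatter), so this position tolerates the change from 10 heavy atoms to 5 without a clear shift. With thiophen-2-yl present in both compounds, the change on a nitrogen on an aromatic ring gives a 2.9-fold higher number from compound 1 to compound 3 (0.46 log units; beyond the scatter), a modest step that goes with the chain rather than the ring. Nothing available explains either step. Open, on these data alone, is whether an amine or a carboxylic acid at this position would move the number beyond the scatter.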